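A few compounds are considered here, and "the series" means these few. Any claim that something is new, unique, unknown or untested is made for them only; others in the source may bear on it.

Measured compounds and their values:

Compound 1, `COc1ccc(-c2cc(/C=C/C(=O)c3ccc(N)cc3)[nH]n2)cc1`: 94%
Compound 2, `COc1ccc(-c2cc(/C=C/C(=O)c3ccc(N)cc3)[nH]n2)cc1OC`: 103%
Compound 3, `COc1cc(C(=O)/C=C/c2cc(-c3cc(OC)c(OC)c(OC)c3)n[nH]2)cc(OC)c1OC`: 101%

All three compounds were tested in a functional assay on NCI-H23 cells (Homo sapiens) for cytotoxicity, read by sulforhodamine B assay, with a stated time of 48 h, tested at 0.1 uM; on this read-out lower numbers stand for a stronger effect and higher numbers for a weaker effect at the one concentration tested. In this assay compound 1 gives 94%, compound 2 gives 103% and compound 3 gives 101%. The three numbers lie close together, and none of the gaps between them is larger than the usual scatter of repeated measurements, so no ordering among them can be read from these data.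

Compound 1 and compound 2 differ in one place: hydrogen in place of methoxy on an aromatic carbon. The step that goes with this change is a number 9 percentage points lower from compound 2 to compound 1 (within the scatter).

Compound 3 is built on a core that differs from the core of compound 2 in several places at once, and that difference is not broken down here.

The unmeasured compound 4, `COc1ccc(-c2cc(/C=C/C(=O)c3cc(OC)c(OC)c(OC)c3)[nH]n2)cc1OC`, is derived from compound 3 by the change (hydrogen in place of methoxy on an aromatic carbon). Among the compounds with values here, this is the same kind of change as the one from compound 2 to compound 1, though the surroundings are not identical: in compound 3 the position is also meta to a methoxy group, which is not so in compound 2. Resting on the step of a number 9 percentage points lower from compound 2 to compound 1 (within the scatter), the step from compound 3 to compound 4 is expected to be a number 4 percentage points lower from compound 3 to compound 4 (within the scatter). Compound 4 is therefore estimated to give 97% in this assay, expected to fall between 85% and 110%.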

Compound 4, a percentage reported as activity, at one concentration (the size of the read-out at that concentration, not a potency): 95%
For compound 4 the middle estimate is 2 percentage points above the measured one, and the stated range covers the measured number.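

In this assay the swap of a methoxy group for hydrogen on an aromatic carbon gives a number 6 percentage points lower from compound 3 to compound 4 (within the scatter) and this fits with the same swap on the other core: the same change on two cores in this assay, a number 9 percentage points lower (within the scatter) from compound 2 to compound 1 and a number 6 percentage points lower (within the scatter) from compound 3 to compound 4, 3 percentage points apart, within the scatter of two such steps. The two steps therefore agree, so in these four compounds the change carries from one core to the other without any visible difference between the cores. Within the data shown here, this does not show that the change has a real effect on either core, since each step on its own stays within the scatter, and the agreement may amount to no more than two small numbers that cannot be told from noise, seen at a single concentration and on only two cores.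

The compounds shown leave open whether another group in place of that methoxy group, such as a hydroxyl group, a chlorine atom or a longer ethoxy chain, would move the number beyond the scatter. They also leave open whether the swap of methoxy for hydrogen would make a readable difference at a higher concentration, where the cells might respond more clearly to these compounds.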